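The source may report more compounds than this note shows. Statements on the series, on what has been measured and on what is new or still open speak of the compounds shown alone.

Compound 1 `FC(F)(F)c1ccc(CSc2nc(Nc3cccc(C(F)(F)F)c3)c3ccccc3n2)cc1` gives 11700 nM in a functional assay on HGC-27 cells (Homo sapiens) for cytotoxicity, read by MTT assay, with a stated time of 72 h; a lower number here means a stronger inhibitor, a higher number a weaker inhibitor. Compound 2 `O=[N+]([O-])c1cccc(Nc2nc(SCc3ccc(C(F)(F)F)cc3)nc3ccccc23)c1` gives > 50000 nM, which is a limit of this assay and not a number.

In this assay compound 2 therefore sits at the limit (the limit of > 50000 nM in this assay, at which 1 of the 2 values shown sits), and only a range is known for it. Among the measured compounds shown here, the one measured step, an at least 4.2-fold higher number from compound 1 to compound 2 (0.63 log units; beyond the scatter), ends at that limit. Compound 3 `O=[N+]([O-])c1ccc(Nc2nc(SCc3ccc(C(F)(F)F)cc3)nc3ccccc23)cc1` differs from compound 2 by 4-nitrophenyl in place of 3-nitrophenyl on a nitrogen on an aromatic ring. No measured step concerns this move of the nitro group, so the numbers shown give no direction for it. The expected step is a number no higher from compound 2 to compound 3 (the limit leaves the size open), not beyond the scatter. Compound 3 is thus estimated at 50000 nM, between 20000 nM and 120000 nM.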

Compound 3, half-maximal inhibitory concentration: 16600 nM
Compound 3: middle estimate off by 3.0-fold (0.48 log units), on the high side; the measured number lies below the stated range.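

On the nitrogen on an aromatic ring, the place of the nitro group on the phenyl ring matters in this assay (an at least 3.0-fold lower number from compound 2 to compound 3 (0.47 log units; beyond the scatter)). Going by these compounds, compound 2 gives a limit and not a number, so the full size of this step is unknown, because the step starts from that limit: (the limit of > 50000 nM in this assay, at which 1 of the 3 values shown sits). As 4-nitrophenyl, the nitro group cannot be told apart from the 3-(trifluoromethyl)phenyl of compound 1 (a 1.4-fold higher number from compound 1 to compound 3 (0.15 log units; within the scatter)).

Still open, on these data alone, is whether an amine or a carboxylic acid in place of the nitro group would give a lower number.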